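Varying the Aryl Group on the Ring Nitrogen

The compounds below may be only part of what the source reports. "The series", "measured", "known", "first", "only" and "open" are said of these compounds alone.

Compound 1 `Cc1ccccc1-n1cc(COc2cccc(NC(=O)Nc3ccc(Cl)c(C(F)(F)F)c3)c2)nn1` gives 3440 nM in a functional assay on HepG2 cells (Homo sapiens) for inhibition, read by MTT assay, with a stated time of 72 h; a higher number here means a weaker inhibitor, a lower number a stronger inhibitor.
Compound 2 `N#Cc1ccc(-n2cc(COc3cccc(NC(=O)Nc4ccc(Cl)c(C(F)(F)F)c4)c3)nn2)cc1` gives 2980 nM in this assay.
Compound 3 `CC(C)c1ccc(-n2cc(COc3cccc(NC(=O)Nc4ccc(Cl)c(C(F)(F)F)c4)c3)nn2)cc1` gives 2470 nM in this assay.

All three compounds share the same core and differ only in the aryl group on the aromatic nitrogen. Compound 3 has the lowest number of the three, but the step of a 1.2-fold lower number from compound 2 to compound 3 (0.08 log units; within the scatter) and the step of a 1.4-fold lower number from compound 1 to compound 3 (0.14 log units; within the scatter) both lie within the scatter, as does the step of a 1.2-fold lower number from compound 1 to compound 2 (0.06 log units; within the scatter), so the three cannot be separated by these data.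

Compound 4 `O=C(Nc1cccc(OCc2cn(-c3cccc(Cl)c3)nn2)c1)Nc1ccc(Cl)c(C(F)(F)F)c1` continues the same theme: 3-chlorophenyl in place of 4-isopropylphenyl on an aromatic nitrogen. Every measured step in this set alters the same aryl group at the same place, and none of them moved this assay beyond the scatter, whether the change was a methyl, a nitrile or an isopropyl on the phenyl ring. On that basis a 3-chlorophenyl is expected to behave like the others, with no step beyond the scatter; the estimated step is a 1.1-fold higher number from compound 3 to compound 4 (0.05 log units; within the scatter). Compound 4 is therefore expected to give 2800 nM in this assay, with a range from 1400 nM to 5600 nM.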

Compound 4, half-maximal inhibitory concentration: 2020 nM
Compound 4: middle estimate off by 1.4-fold (0.14 log units), on the high side, within the range that was stated.
By their numbers in this assay, from the lowest: compounds 4, 3, 2 and 1 (each within the scatter of the next).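

For the compounds shown here, with 3-chlorophenyl, chlorine enters the aryl group on the aromatic nitrogen for the first time in this set, and the position still shows no separation in this assay: the new compound gives a 1.2-fold lower number from compound 3 to compound 4 (0.09 log units; within the scatter) and a 1.5-fold lower number from compound 2 to compound 4 (0.17 log units; within the scatter) and also a 1.7-fold lower number from compound 1 to compound 4 (0.23 log units; within the scatter) in the same reading. Going by these compounds alone, that last step is the widest gap among the four compounds, yet it too stays within the scatter, so 2-methylphenyl, 4-cyanophenyl, 4-isopropylphenyl and 3-chlorophenyl on this nitrogen cannot be told apart by these numbers, and no compound here goes against that. Nothing available here accounts for this flat response to the change of aryl group at this place.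

The compounds shown leave open whether a carboxylic acid or an amine on the phenyl ring, or a benzyl group or a plain alkyl chain in place of that ring, would move the number beyond the scatter. Equally open, as far as these compounds go, is what any change outside this aryl group, in the shared core, would do to the number.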